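The compounds below may be only part of what the source reports. "The series", "measured", "known", "first", "only" and "open" are said of these compounds alone.

Of the compounds shown here, two sharing one core have been measured in an in vitro assay on HEK-tsA201 cells for antagonist activity at Neuronal acetylcholine receptor; alpha4/beta2 (Homo sapiens), read by fluorescence and calcium flux; a higher number here means a weaker inhibitor, a lower number a stronger inhibitor. Compound 1 `C=C(C)COc1ccc(C(=O)Nc2cccc(C)n2)cc1` gives 19600 nM, and compound 2 `CCCOc1ccc(C(=O)Nc2cccc(C)n2)cc1` gives 7500 nM. For the measured compounds named here, the one step between them, a 2.6-fold lower number from compound 1 to compound 2 (0.42 log units; beyond the scatter), lies on the chain attached to the ring oxygen. Going by the values given here, on the numbers seen so far compound 2 stands lowest of the two, with compound 1 as its only neighbour at a higher number.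

Compound 3 `CCCCNc1cccc(NC(=O)c2ccc(OCCC)cc2)n1` differs from compound 2 in butylamino in place of methyl on an aromatic carbon. Among the compounds with values here, no measured step touches this part of the molecule: the step from compound 1 to compound 2 concerns the ether chain and says nothing about the ring carbon where the new change is made. An expectation for compound 3 therefore rests on the value of compound 2 alone, and the step of a 1.3-fold lower number from compound 2 to compound 3 (0.10 log units; within the scatter) is expected to be small, in neither direction with any confidence, with a wide range around it. Compound 3 is estimated to give 6000 nM in this assay, with a range from 1500 nM to 25000 nM.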

Compound 3, half-maximal inhibitory concentration: 54100 nM
For compound 3 the middle estimate is 9.0-fold (0.96 log units) below the measured one; the measured number lies above the stated range.
By their numbers in this assay, from the lowest: compound 2; then compound 1; then compound 3.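

In this assay, for the compounds shown here, the butylamino for methyl change on the aromatic carbon next to the ring nitrogen gives a 7.2-fold higher number from compound 2 to compound 3 (0.86 log units; beyond the scatter), and this is the first measured change at this carbon. It shows that the position is not indifferent to what it carries: a larger group bearing a nitrogen, a hydrogen-bond donor and a hydrogen-bond acceptor moves the number upward by more than the scatter, so for this pair methyl is the better of the two groups. Going by these compounds alone, the single step changes the chain and the nitrogen together, so it cannot divide the rise between them, and no measurement at hand explains it.

What the compounds shown leave open is which part of butylamino matters: a plain amino group, methylamino or an unbranched pentyl chain on this carbon would begin to separate the nitrogen from the length of the chain. On these data alone, it also remains open whether the same change would have a similar effect with the 2-methylallyl ether chain of compound 1 in place of the propyl ether chain of compound 2.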